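Cyclopentyloxy-methoxybenzamide series: anilide to pyridyl amide

The compounds below may be only part of what the source reports. "The series", "measured", "known", "first", "only" and "open" are said of these compounds alone.

Compound 2 `COc1ccc(C(=O)Nc2c(C)cccc2Cl)cc1OC1CCCC1` gives 100 nM in an assay on isolated protein for inhibition of phosphodiesterase 4A (Sus scrofa) (on this read-out higher numbers stand for weaker inhibition and lower numbers for stronger inhibition), the lowest of the three numbers in hand. Within the data shown here, compound 1 `COc1ccc(C(=O)Nc2ccccc2C)cc1OC1CCCC1` gives 300 nM, and the step of a 3.0-fold lower number from compound 1 to compound 2 (0.48 log units; beyond the scatter) is the only single-place change measured. Compound 3 `COc1ccc(C(=O)Nc2ccccc2Cl)cc1OC(C)=O` gives 70000 nM; it differs from compound 2 in more than one place, so only the two values themselves can be compared. Compound 4 `COc1ccc(C(=O)Nc2ccncc2)cc1OC1CCCC1` carries pyridin-4-yl in place of 2-chloro-6-methylphenyl on an amide-type nitrogen. Among the measured compounds shown here, no measured step touches the group on the amide nitrogen beyond the chloro addition, so there is no direct precedent for this change. The expectation is a weakening, with compound 4 estimated at 1500 nM in this assay, range 300 nM to 8000 nM, a step of a 15-fold higher number from compound 2 to compound 4 (1.18 log units; beyond the scatter).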

Compound 4, half-maximal inhibitory concentration: 800 nM
For compound 4 the middle estimate is 1.9-fold (0.27 log units) above the measured one; low and high end bracket the measured number.
By their numbers in this assay, from the lowest: compound 2; then compound 1; then compound 4; then compound 3.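

Pyridin-4-yl is accepted on the amide-type nitrogen with some loss: the change gives an 8.0-fold higher number from compound 2 to compound 4 (0.90 log units; beyond the scatter) and a 2.7-fold higher number from compound 1 to compound 4 (0.43 log units; beyond the scatter) and both steps are modest. Among these compounds, these are the first steps that replace the whole aromatic ring at this position, but each swaps several features at once, so the loss cannot be divided between the ring nitrogen and the missing chloro or methyl groups. No measurement here bears on the cause of this loss.

An unsubstituted phenyl and a pyridin-3-yl would help separate these contributions. On these data alone, whether adding chloro and methyl groups to the pyridin-4-yl ring recovers inhibition also remains open.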